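Side-chain change from compound 2 to compound 4

The source may hold more compounds than are shown below. What is called first, only, known or untested is meant among the compounds shown, and "the series" means these compounds.

In a functional assay (lung parenchyma) for displacement of a labelled ligand, with Cavia porcellus as the target (on this read-out lower numbers stand for stronger inhibition and higher numbers for weaker inhibition), compound 2 `CCN(CC)C(=O)/C=C/c1cn(Cc2ccc(C(=O)NS(=O)(=O)c3ccccc3C)cc2OC)c2cc(C(=O)NCC3CCCC3)ccc12` gives 4.9 nM, the highest of the three numbers recorded in this series. Compound 1 `CCN(CC)C(=O)CCn1cc(Cc2ccc(C(=O)NS(=O)(=O)c3ccccc3C)cc2OC)c2cc(C(=O)NCC3CCCC3)ccc21` gives 0.43 nM and compound 3 `COc1cc(C(=O)NS(=O)(=O)c2ccccc2C)ccc1Cc1cn(C)c2ccc(NC(=O)CC3CCCC3)cc12` gives 0.3 nM; both gaps to compound 2 lie beyond the scatter. Compound 4 `COc1cc(C(=O)NS(=O)(=O)c2ccccc2C)ccc1Cn1cc(CC(C)C(=O)N(C)C)c2ccc(C(=O)NCC3CCCC3)cc21` has not been measured. It differs from compound 2 in one place: 2-(dimethylcarbamoyl)propyl in place of 2-(diethylcarbamoyl)ethenyl on an aromatic carbon. Going by the values given here, no step between measured compounds covers this change, so the expectation rests on where compound 2 stands relative to compound 1 and compound 3, both with lower numbers. The step is expected to run towards a lower number, a 7.0-fold lower number from compound 2 to compound 4 (0.85 log units; beyond the scatter). For compound 4 the estimated value in this assay is 0.7 nM, with a range from 0.2 nM to 2.5 nM.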

Compound 4, inhibition constant: 2.32 nM
Estimate against measurement, compound 4: 3.3-fold (0.52 log units) below, and the stated range covers the measured number.
By their numbers in this assay, from the lowest: compounds 3 and 1 (each within the scatter of the next); then compound 4; then compound 2.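

In this assay the swap of 2-(diethylcarbamoyl)ethenyl for 2-(dimethylcarbamoyl)propyl on this aromatic carbon gives a 2.1-fold lower number from compound 2 to compound 4 (0.32 log units; beyond the scatter) and this modest step lies beyond the scatter. This position therefore accepts a chain with one double bond fewer outside the aromatic rings without a rise in the number on this read-out. Nothing measured here explains the step.

On these data alone, the change alters the chain and the amide substituents together, and the share of each stays open. Also open, as far as these compounds go, is how a carboxylic acid or a primary amine in place of the tertiary amide would read at this position.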